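The source may report more compounds than this note shows. Statements on the series, on what has been measured and on what is new or still open speak of the compounds shown alone.

Series notes, amides of the shared core. Compound 1 `CC(C)C(=O)N1CC2CC(C1)N2` gives 19000 nM in an assay on SH-EP1 cells for agonist activity at Neuronal acetylcholine receptor; alpha4/beta2 (Homo sapiens), read by FLIPR and calcium flux; a higher number here means that more compound is needed for the effect, a lower number that less compound is needed; compound 2 `O=C(C1CCC1)N1CC2CC(C1)N2` gives 2900 nM; compound 3 `O=C([C@@H]1C[C@@H]1F)N1CC2CC(C1)N2` gives 120 nM, the lowest of the three numbers. Within the data shown here, the steps so far all exchange the group on the carbonyl carbon: a 6.6-fold lower number from compound 1 to compound 2 (0.82 log units; beyond the scatter), a 160-fold lower number from compound 1 to compound 3 (2.20 log units; beyond the scatter), a 24-fold lower number from compound 2 to compound 3 (1.38 log units; beyond the scatter). Compound 4 `O=C([C@H]1C[C@@H]1F)N1CC2CC(C1)N2` differs from compound 3 only in this: the two compounds have the same atoms and bonds; at least one stereo element is drawn with a configuration in one of them and without one in the other: 1 of 4 stereo elements differ; a stereocentre at a saturated ring carbon is drawn S in compound 3 and R in compound 4. Among the measured compounds shown here, no measured step alters a stereocentre alone, so none bears directly on this change; the direction is open, though a shift beyond the scatter is plausible. Compound 4 is therefore expected, with wide uncertainty, to give 350 nM in this assay, between 60 nM and 2500 nM, an estimated step of a 2.9-fold higher number from compound 3 to compound 4 (0.46 log units; beyond the scatter).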

Compound 4, half-maximal effective concentration: 850 nM
Estimate against measurement, compound 4: 2.4-fold (0.39 log units) below; the range from low to high includes it.
By their numbers in this assay, from the lowest: compound 3; then compound 4; then compound 2; then compound 1.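

In this assay the configuration at this saturated ring carbon counts on its own, with a 7.1-fold higher number from compound 3 to compound 4 (0.85 log units; beyond the scatter) and no change in atoms or bonds. The 2-fluorocyclopropyl group keeps the lower number against the earlier groups, with a 3.4-fold lower number from compound 2 to compound 4 (0.53 log units; beyond the scatter) and with a 22-fold lower number from compound 1 to compound 4 (1.35 log units; beyond the scatter) in this drawn form too. The step is limited as a comparison of two fully defined forms: the fact that one of compounds 3 and 4 is drawn with a defined configuration and the other without, at the place where they differ.

From the compounds shown here alone, what a plain cyclopropyl or a 2,2-difluorocyclopropyl on the carbonyl carbon would give stays open. The share of the fluorine in these steps therefore cannot be read from the compounds shown.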